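The compounds below may be only part of what the source reports. "The series", "measured", "known", "first", "only" and "open" are said of these compounds alone.

Measured compounds:
Compound 1, `O=C(/C=C/c1ccc(Cl)cc1)C[C@@H]1O[C@H](CO)[C@@H](O)[C@H](O)[C@H]1O`, in an assay for inhibition of glucose-6-phosphatase catalytic subunit 1 (Rattus norvegicus), tested at 100 uM (a higher number here means more inhibition at the concentration tested (going by the name of the read-out), a lower number less inhibition), compound 1 gives -25.3%.
Compound 2, `O=C(/C=C/c1ccc(Cl)cc1)C[C@@H]1OC[C@@H](O)[C@H](O)[C@H]1O`, in this assay compound 2 gives 4.7%.

Within the data shown here, compound 1 stands lowest of the two numbers; the nearest value is that of compound 2, and the one step between them is a number 30 percentage points higher from compound 1 to compound 2 (beyond the scatter), a change of hydrogen in place of hydroxymethyl on a saturated ring carbon of the shared core.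

The compound still to be measured is compound 3, `O=C(/C=C/c1cccnc1)C[C@@H]1O[C@H](CO)[C@@H](O)[C@H](O)[C@H]1O`. It differs from compound 1 only at the far end of the chain: pyridin-3-yl in place of 4-chlorophenyl on a double-bonded chain carbon bound to a double-bonded chain carbon. Among the measured compounds shown here, no measured step touches this part of the molecule; the single known step from compound 1 to compound 2 concerns the core and says nothing about the aromatic ring. Without any comparison of its kind, the step from compound 1 to compound 3 in this assay is expected to stay within the scatter, with no direction favoured, that is a number 10.3 percentage points higher from compound 1 to compound 3 (beyond the scatter). For compound 3 the estimated value in this assay is therefore -15%, with a range from -40% to 10%.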

Compound 3, a percentage reported as inhibition, at one concentration (the size of the read-out at that concentration, not a potency): -8.1%
Compound 3: the middle estimate sits 6.9 percentage points below what was measured; the range from low to high includes it.
By their numbers in this assay, from the lowest: compound 1; then compound 3; then compound 2.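

In this assay, the far end of the chain proves not to be a silent position: pyridin-3-yl in place of 4-chlorophenyl on a double-bonded chain carbon bound to a double-bonded chain carbon gives a number 17.2 percentage points higher from compound 1 to compound 3 (beyond the scatter). Among these compounds, the only earlier step concerned the core, so this is the first sign that the aromatic ring also moves the read-out, although compound 3, at -8.1%, still stands below zero, as compound 1 does at -25.3%. Nothing shown here accounts for why this exchange of rings moves the number.

The compounds shown leave open whether the step follows the loss of the chlorine or the arrival of the ring nitrogen, which a plain phenyl at this place would help to tell apart, and whether pyridin-4-yl or pyridin-2-yl would read like pyridin-3-yl. Also open, from the compounds shown here alone, is whether the same exchange of rings would give a similar step on the core of compound 2, which carries hydrogen in place of hydroxymethyl, and whether an amine or a carboxylic acid on the aromatic ring would lift the number further.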